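A few compounds are considered here, and "the series" means these few. Any claim that something is new, unique, unknown or untested is made for them only; others in the source may bear on it.

Three compounds have been measured in an assay on isolated protein for inhibition of matrix metalloproteinase-9 (Homo sapiens); a higher number here means a weaker inhibitor, a lower number a stronger inhibitor:

Compound 1 `C=C[C@@H]1OC(/C=C/c2ccccc2)=N[C@H]1CO`: 40000 nM
Compound 2 `C=C[C@@H]1OC(c2ccc(Oc3ccccc3)cc2)=N[C@H]1CO`: 32000 nM
Compound 3 `C=C[C@@H]1OC(/C=C/c2ccccc2)=N[C@H]1S`: 94000 nM

Compound 2 gives the lowest number of the three, but compound 1 sits within the usual scatter of it, while compound 3 lies beyond it. Compound 4 `C=C[C@@H]1OC(c2ccccc2)=N[C@H]1CO` is compound 2 with one change: hydrogen in place of phenoxy on an aromatic carbon. Going by the values given here, the only measured step, a 2.4-fold higher number from compound 1 to compound 3 (0.37 log units; beyond the scatter), concerns a group on the saturated ring and does not touch the aromatic part, so no measured step bears directly on this change. Compound 1 and compound 2 differ in more than one place, and their values sit within the scatter of each other. Without a direct guide, a modest weakening is expected, a 1.9-fold higher number from compound 2 to compound 4 (0.27 log units; within the scatter). Compound 4 is estimated at 60000 nM, with a range from 20000 nM to 180000 nM.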

Compound 4, inhibition constant: > 4000000 nM
Compound 4: a limit, no number (the forecaster's own chance of this, stated with the estimate: 15%); middle value at least 66-fold (1.82 log units) from the limit.
By their numbers in this assay, from the lowest: compounds 2 and 1 (each within the scatter of the next); then compound 3. At a limit, above all of these: compound 4.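

Hydrogen in place of phenoxy on this aromatic carbon gives an at least 120-fold higher number from compound 2 to compound 4 (2.09 log units; beyond the scatter), far larger than the only earlier step, which concerned a group on the saturated ring. Going by these compounds alone, the phenoxy group at this position therefore counts for much of the inhibition seen with compound 2, which the earlier compounds could not show. Compound 4 stands at a limit, not a number: the limit of > 4000000 nM in this assay, at which 1 of the 4 values shown sits.

Still open, on these data alone, is which part of phenoxy matters. A phenyl or a methoxy group on this aromatic carbon would separate the second ring from the oxygen.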